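The source may report more compounds than this note shows. Statements on the series, on what has been measured and on what is new or still open speak of the compounds shown alone.

Of the compounds shown here, two from one series have been tested in an assay on A549 cells for inhibition of transcription factor p65 (Homo sapiens), read by fluorescence, with a stated time of 2 h; on this read-out higher numbers stand for weaker inhibition and lower numbers for stronger inhibition. Compound 1, `COc1ccc(/C=C/C(=O)c2ccc(NC(C)=O)c(-c3ccc(F)cc3)c2)cc1OC`, gives 2650 nM in this assay. Compound 2, `COc1cc(/C=C/C(=O)c2ccc(N)c(-c3ccc(F)cc3)c2)cc(OC)c1OC`, gives 11600 nM, the higher of the two numbers, and its gap to compound 1 lies beyond the usual scatter. Among the compounds with values here, these two compounds differ in more than one place, so no single step connects them. Compound 3, `COc1ccc(/C=C/C(=O)c2ccc(N)c(-c3ccc(F)cc3)c2)cc1OC`, has not yet been measured; it is derived from compound 2 by one change: hydrogen in place of methoxy on an aromatic carbon. Compound 1 shares the methoxy pattern of compound 3 but carries an acetyl on the amine nitrogen rather than a free amine; in this assay compound 1 gives 2650 nM, which is only a loose pointer. The number for compound 3 is expected to move toward that of compound 1, an expected step of a 1.9-fold lower number from compound 2 to compound 3 (0.29 log units; within the scatter), though a result within the scatter of compound 2 would not surprise. Compound 3 is therefore estimated at 6000 nM, within a range from 2500 nM to 15000 nM.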

Compound 3, half-maximal inhibitory concentration: > 50000 nM
Compound 3 was reported as a limit; the forecaster's own chance of this, stated with the estimate: 5%; middle value at least 8.3-fold (0.92 log units) away from the limit.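

In this assay compound 3 stands only as a limit, not as a number: the limit of > 50000 nM in this assay, at which 1 of the 3 values shown sits. Even so, the methoxy group at this place clearly counts: hydrogen in its place gives an at least 4.3-fold higher number from compound 2 to compound 3 (0.63 log units; beyond the scatter), an effect that compounds 1 and 2 could not isolate, as they differ in more than one place. On the nitrogen, hydrogen in place of acetyl gives an at least 18-fold higher number from compound 1 to compound 3 (1.27 log units; beyond the scatter), so either the extra methoxy group or the acetyl is enough to bring back a measured value.

On these data alone, the true size of both steps stays unknown, and so does the effect of another group at this place, such as a hydroxyl or a fluorine. Also open, as far as these compounds go, is whether the extra methoxy group and the acetyl on the nitrogen would add up when carried together on the shared core.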